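Opening the piperidin-3-yl group into a chain

This account rests on a few compounds, and the source may have more. Where it says the series, first, only, none or still open, it means among the compounds named here.

In a functional assay on SK-BR-3 cells (Homo sapiens) for antiproliferative activity (on this read-out higher numbers stand for weaker inhibition and lower numbers for stronger inhibition), three compounds have been measured:
compound 1, `CC(=O)Oc1ccc(C(=O)Nc2cc3ccc(OCC4CCCN(C)C4)c(C)c3oc2=O)cc1CC=C(C)C`, 740 nM
compound 2, `CC(=O)Oc1ccc(C(=O)Nc2cc3ccc(OCCC4CCCCN4)c(C)c3oc2=O)cc1CC=C(C)C`, 640 nM
compound 3, `CC(C)=CCc1cc(C(=O)Nc2cc3ccc(OCC4CCCNC4)c(C)c3oc2=O)ccc1O`, 600 nM

Compound 3 carries the lowest of the three numbers, yet its distance to compound 2 and to compound 1 lies within the scatter, so the three stand level in this assay. Among the measured compounds shown here, the one step between compounds that differ in a single place, a 1.2-fold lower number from compound 1 to compound 2 (0.06 log units; within the scatter), concerns the same region, the group on the saturated chain carbon bound to the oxygen on the aromatic ring, and it stayed within the scatter.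

Compound 4, `CC(C)=CCc1cc(C(=O)Nc2cc3ccc(OCCCNC(C)C)c(C)c3oc2=O)ccc1O`, differs from compound 3 in that region alone: 2-(isopropylamino)ethyl in place of piperidin-3-yl on a saturated chain carbon bound to an oxygen on an aromatic ring. The one six-membered non-aromatic ring is traded for a group with no ring, while the count of heavy atoms, donors and acceptors is unchanged. For the measured compounds named here, the only comparable step gave no movement beyond the scatter, so compound 4 is expected to stay close to compound 3, with a 1.1-fold higher number from compound 3 to compound 4 (0.03 log units; within the scatter) as the expected step. The estimate for compound 4 is 650 nM, between 300 nM and 1400 nM.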

Compound 4, half-maximal inhibitory concentration: 750 nM
For compound 4 the middle estimate is 1.2-fold (0.06 log units) below the measured one; the measured number falls inside the stated range.
By their numbers in this assay, from the lowest: compounds 3, 2, 1 and 4 (each within the scatter of the next).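

In this assay, the step of a 1.3-fold higher number from compound 3 to compound 4 (0.10 log units; within the scatter) shows that, on a saturated chain carbon bound to an oxygen on an aromatic ring, piperidin-3-yl can give way to 2-(isopropylamino)ethyl with no movement beyond the scatter. The earlier step at this place swapped one ring-bearing group for another, whereas this one leaves no ring in the group, so for this pair the ring is not required for the number to hold. Nothing at hand explains why the two compounds stand level.

The compounds shown leave open whether the amine itself matters here, which a plain methoxy or a hydroxyl-ending chain in place of (piperidin-3-yl)methoxy would test. Also open is whether a carboxylic acid or a longer chain at this place would move the number beyond the scatter, which no step shown here has done.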